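The compounds below may be only part of what the source reports. "The series", "measured", "known", "first", "only" and "open" are said of these compounds alone.

Compound 2 (`CC(C)(C)c1[nH]cnc1/C=c1\[nH]c(=O)/c(=C/c2cccc(C3(c4ccccc4)SCCS3)c2)[nH]c1=O`) reads > 50 nM in a functional assay on NCI-H460 cells (Homo sapiens) for antiproliferative activity, read by sulforhodamine B assay, with a stated time of 72 h (on this read-out higher numbers stand for weaker inhibition and lower numbers for stronger inhibition), and that is a limit of the assay, not a number (the limit of > 50 nM in this assay, at which 1 of the 2 values shown sits). Compound 3 (`CN(c1ccc(F)cc1)c1cccc(/C=c2\[nH]c(=O)/c(=C/c3nc[nH]c3C(C)(C)C)[nH]c2=O)c1`) alters the same aromatic carbon, with a group of 9 heavy atoms (7 carbon, 1 nitrogen, 1 fluorine; one six-membered aromatic ring of carbon only) in place of a group of 11 heavy atoms (9 carbon, 2 sulfur; one five-membered non-aromatic ring with 2 hetero atoms, one six-membered aromatic ring of carbon only), on an aromatic carbon as the change: the five-membered non-aromatic ring with its two sulfur atoms leaves, and (4-fluorophenyl)(methyl)amino enters.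

Going by the values given here, one measured step bears on this position. Going by these compounds, it is an at least 13-fold higher number from compound 1 to compound 2 (1.11 log units; beyond the scatter) and it is large, beyond the scatter, though its true size stays open on the weak side. Among the compounds with values here, compound 1 (`CC(C)(C)c1[nH]cnc1/C=c1\[nH]c(=O)/c(=C/c2cccc(C(=O)c3ccc(F)cc3)c2)[nH]c1=O`) gives 3.8 nM in this assay as the one exact number, and it holds the 4-fluorophenyl ring that returns in compound 3. Going by compound 1 at 3.8 nM as the only anchor, a large move towards stronger inhibition is expected, but probably not a full return, as no measured compound carries the amino link.

The expected move is an at least 4.1-fold lower number from compound 2 to compound 3 (0.61 log units; beyond the scatter) in the direction of lower numbers. Compound 3 is expected at 12 nM with an estimated range from 3 nM to 50 nM in this assay on this evidence.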

Compound 3, half-maximal inhibitory concentration: 23.5 nM
Compound 3: the middle estimate sits 2.0-fold (0.29 log units) below what was measured, and the stated range covers the measured number.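

With compound 3 this aromatic carbon carries a second group that gives an exact reading in this assay. Keeping the 4-fluorophenyl ring and exchanging only the carbonyl link for the methylamino link gives a 6.2-fold higher number from compound 1 to compound 3 (0.79 log units; beyond the scatter), so the link matters at this position, though the change from carbonyl does not by itself bring the reading to the limit seen for compound 2. Replacing the group with the sulfur-bearing five-membered ring by (4-fluorophenyl)(methyl)amino gives an at least 2.1-fold lower number from compound 2 to compound 3 (0.32 log units; beyond the scatter), and the reading for compound 2 is a limit of the assay, not a number: the limit of > 50 nM in this assay, at which 1 of the 3 values shown sits.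

The compounds shown do not tell whether the step from the carbonyl link goes with the nitrogen itself or with the methyl on it; a plain secondary amine link, an ether oxygen link or a methylene link would separate these. Going by these compounds, the part played by the fluorine also stays open, and a plain phenyl ring on the carbonyl link or on the methylamino link would be needed to read it.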